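The compounds below may be only part of what the source reports. "The series", "measured", "known", "first", "only" and "open" are said of these compounds alone.

Working notes on the series. Compound 1 `O=C(COc1cccc2ccccc12)N/N=C/c1cccc(O)c1` gives 62.7 ug/mL in an ADME assay on HEL cells (Homo sapiens) for cytotoxicity (on this read-out lower numbers stand for higher toxicity in this test and higher numbers for lower toxicity in this test), the smallest of the three numbers at hand, though both other compounds lie within the scatter of it. Compound 2 `O=C(COc1cccc2ccccc12)N/N=C/c1ccccc1Br` gives 100 ug/mL and compound 3 `O=C(COc1cccc2ccccc12)N/N=C/c1ccc(Br)cc1` gives 100 ug/mL; the steps of a 1.6-fold higher number from compound 1 to compound 2 (0.20 log units; within the scatter) and a 1.6-fold higher number from compound 1 to compound 3 (0.20 log units; within the scatter) stay within the scatter, as does no change at the digits printed from compound 2 to compound 3 (within the scatter). Compound 4 `O=C(COc1cccc2ccccc12)N/N=C/c1cccc([N+](=O)[O-])c1` differs from compound 1 by nitro in place of hydroxy on an aromatic carbon. Within the data shown here, no measured step exchanges hydroxy for nitro; the nearest analogies, where hydroxy leaves in a 1.6-fold higher number from compound 1 to compound 2 (0.20 log units; within the scatter) and a 1.6-fold higher number from compound 1 to compound 3 (0.20 log units; within the scatter), were both small, so the expected step is a 1.3-fold higher number from compound 1 to compound 4 (0.11 log units; within the scatter), not beyond the scatter. Compound 4 is estimated at 80 ug/mL, with a range from 40 ug/mL to 100 ug/mL.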

Compound 4, half-maximal cytotoxic concentration: 61.2 ug/mL
Estimate against measurement, compound 4: 1.3-fold (0.12 log units) above, and the stated range covers the measured number.
By their numbers in this assay, from the lowest: compounds 4, 1, 2 and 3 (each within the scatter of the next).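

Among these compounds, with a 1.0-fold lower number from compound 1 to compound 4 (0.01 log units; within the scatter) in this assay, this is the first step that changes the group alone on this aromatic carbon, meta to a large group; the earlier steps to the 2-bromophenyl and 4-bromophenyl compounds changed the group and its place together. Replacing hydroxy with nitro removes the hydrogen-bond donor and adds heavy atoms, yet the step stays within the scatter. No available measurement offers an explanation for this result.

Going by these compounds, whether an amine or a carboxylic acid at this position would also stay within the scatter of compound 1 remains open. So does whether nitro would behave the same way at another place on the ring.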